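Swapping a fluoro for a benzyloxy on the anilino ring

This account rests on a few compounds, and the source may have more. Where it says the series, first, only, none or still open, it means among the compounds named here.

Of the compounds shown here, three sharing one core have been tested in a functional assay on A549 cells (Homo sapiens) for antiproliferative activity, read by MTT assay, with a stated time of 72 h; a higher number here means a weaker inhibitor, a lower number a stronger inhibitor. Compound 1 `COc1cc2ncnc(Nc3ccc(F)c(Cl)c3)c2cc1OCCCCC(=O)Nc1ccc(S(N)(=O)=O)cc1` gives 15500 nM. Compound 3 `CCc1ccc(Nc2ncnc3cc(OC)c(OCCCCC(=O)Nc4ccc(S(N)(=O)=O)cc4)cc23)cc1` gives 12100 nM. Compound 2 `COc1ccc(Nc2ncnc3cc(OC)c(OCCCCC(=O)Nc4ccc(S(N)(=O)=O)cc4)cc23)cc1OC` reaches only the limit of > 40000 nM, so for it no number is known. Among the two numbers, compound 1 stands highest, but its gap to compound 3, a 1.3-fold lower number from compound 1 to compound 3 (0.11 log units; within the scatter), lies within the scatter. The step of an at least 2.5-fold higher number from compound 1 to compound 2 (0.41 log units; beyond the scatter) lies beyond the scatter, and so does an at least 3.3-fold lower number from compound 2 to compound 3 (0.51 log units; beyond the scatter); each of these steps exchanges the whole group on the nitrogen on the aromatic ring.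

Compound 4 `COc1cc2ncnc(Nc3ccc(OCc4cccc(F)c4)c(Cl)c3)c2cc1OCCCCC(=O)Nc1ccc(S(N)(=O)=O)cc1` differs from compound 1 at one spot only: (3-fluorobenzyl)oxy in place of fluoro on an aromatic carbon. Going by the values given here, no measured step makes this particular exchange, so the measured steps show only that changes on this ring can move the number beyond the scatter, upward in one case and within the scatter in another. For compound 4 a modest lowering of the number is therefore expected, with considerable uncertainty about its size. The step of a 2.6-fold lower number from compound 1 to compound 4 (0.41 log units; beyond the scatter) is the estimate for compound 4. Compound 4 is expected to give 6000 nM, within a range from 1500 nM to 25000 nM.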

Compound 4, half-maximal inhibitory concentration: 7860 nM
Estimate against measurement, compound 4: 1.3-fold (0.12 log units) below; the range from low to high includes it.
By their numbers in this assay, from the lowest: compounds 4, 3 and 1 (each within the scatter of the next). At a limit, above all of these: compound 2.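

Unlike the earlier steps, which exchange the whole group on the nitrogen, this change keeps the chloro group and alters one spot on the ring, para to a large group. In this assay, replacing fluoro (1 heavy atom) with (3-fluorobenzyl)oxy (9 heavy atoms, including one six-membered aromatic ring of carbon only) gives a 2.0-fold lower number from compound 1 to compound 4 (0.29 log units; within the scatter) and therefore shows that this much larger group at this spot leaves the number within the scatter of the fluoro compound. The data shown offer no measured property that would explain this outcome.

The compounds shown leave open whether the fluorine on the benzyl ring contributes anything, a question that an unsubstituted benzyloxy group or a 4-fluorobenzyloxy group at the same spot could address. They also leave open how this spot would respond to quite different groups, such as an amine, a carboxylic acid or a longer alkyl chain, and whether the chloro group must remain in place for the large group to be accommodated in this way.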